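A few compounds are considered here, and "the series" means these few. Any claim that something is new, unique, unknown or untested is made for them only; others in the source may bear on it.

Compound 1 `O=C(/C=C/c1ccccc1)OCC1COCCOCCOCCOCCOCCO1` gives 48000 nM
Compound 2 `O=C(CCCCC1CCCCC1)OCC1COCCOCCOCCOCCOCCO1` gives 71000 nM

In a functional assay on HeLa cells (Homo sapiens) for inhibition, read by sulforhodamine B assay, with a stated time of 48 h (a lower number here means a stronger inhibitor of growth, a higher number a weaker inhibitor of growth), compound 2 stands at 71000 nM and has only compound 1 to be compared with. The gap between them, a 1.5-fold higher number from compound 1 to compound 2 (0.17 log units; within the scatter), came with 4-cyclohexylbutyl in place of 2-phenylethenyl on a carbonyl carbon, and these two values do not separate.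

Compound 3 `CC/C=C/CC(=O)OCC1COCCOCCOCCOCCOCCO1` has not yet been measured. It keeps the shared core but carries but-1-en-1-yl in place of 3-cyclohexylpropyl on a saturated chain carbon bound to a carbonyl carbon, a difference counted as but-1-en-1-yl in place of 3-cyclohexylpropyl on a saturated chain carbon bound to a carbonyl carbon when set against compound 2. Read one bond further out, this is 4-cyclohexylbutyl to pent-2-en-1-yl.

Within the data shown here, only one measured step bears on this change, and it also exchanged the group on the carbonyl carbon. Its size, a 1.5-fold higher number from compound 1 to compound 2 (0.17 log units; within the scatter), gives no reason to expect a step beyond the scatter in this assay and no firm direction. Among the measured compounds shown here, no measured compound carries but-1-en-1-yl, so the range is kept wide. The expected step is a 1.1-fold lower number from compound 2 to compound 3 (0.04 log units; within the scatter) and would leave the number close to where it stands. For compound 3 the estimated value is 65000 nM with an expected range of 35000 nM to 120000 nM in this read-out.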

Compound 3, concentration for 50% growth inhibition: > 100000 nM
Compound 3 ended at the assay's limit; the forecaster's own chance of this, stated with the estimate: 15%; at least 1.5-fold (0.18 log units) between middle value and limit.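

In this assay compound 3 gives > 100000 nM, and this is a limit of the assay, not a number. Among these compounds, replacing 2-phenylethenyl with pent-2-en-1-yl on a carbonyl carbon goes with an at least 2.0-fold higher number from compound 1 to compound 3 (0.31 log units; beyond the scatter), the first step in this small set that clears the scatter, so the group at this place can shift the read-out. Replacing 3-cyclohexylpropyl with but-1-en-1-yl on a saturated chain carbon bound to a carbonyl carbon goes with an at least 1.4-fold higher number from compound 2 to compound 3 (0.14 log units; that floor lies within the scatter), so this floor does not separate the pair, and the true size of the step stays unknown because compound 3 sits at the limit: the limit of > 100000 nM in this assay, at which 1 of the 3 values shown sits.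

That last change removes the six-membered ring and also cuts the group from 9 heavy atoms to 4, so the compounds shown cannot tell which of the two matters, or whether the double bond of but-1-en-1-yl plays any part. On these data alone, how a saturated pentyl chain, a longer chain, or a chain ending in an amine or a carboxylic acid would read in this assay also stays open.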